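The source may report more compounds than this note shows. Statements on the series, on what has been measured and on what is new or still open speak of the compounds shown alone.

Among the measured compounds shown here, compound 3 `O=C1O[C@H]([C@@H](O)Cn2cc(CNS(=O)(=O)c3ccc(Cl)cc3)nn2)C(OCc2ccccc2)=C1OCc1ccccc1` gives 13600 nM in a functional assay on HeLa cells (Homo sapiens) for antiproliferative activity, read by MTT assay, with a stated time of 72 h (a higher number here means a weaker inhibitor, a lower number a stronger inhibitor), the second highest of the three numbers so far. Compound 1 `O=C1O[C@H]([C@@H](O)Cn2cc(-c3ccc(Br)cc3)nn2)C(OCc2ccccc2)=C1OCc1ccccc1` gives 3910 nM and compound 2 `O=C1O[C@H]([C@@H](O)Cn2cc(C3CC3)nn2)C(OCc2ccccc2)=C1OCc1ccccc1` gives 26500 nM. The gap a 1.9-fold lower number from compound 2 to compound 3 (0.29 log units; within the scatter) is within the scatter, whereas a 3.5-fold higher number from compound 1 to compound 3 (0.54 log units; beyond the scatter) and a 6.8-fold higher number from compound 1 to compound 2 (0.83 log units; beyond the scatter) both lie beyond it. Compound 4 `Cc1ccc(-c2cn(C[C@H](O)[C@H]3OC(=O)C(OCc4ccccc4)=C3OCc3ccccc3)nn2)cc1` differs from compound 3 by the change (4-methylphenyl in place of (((4-chlorophenyl)sulfonyl)amino)methyl on an aromatic carbon). The step that bears on this is a 3.5-fold higher number from compound 1 to compound 3 (0.54 log units; beyond the scatter), which ran in the opposite direction when a six-membered aromatic ring was exchanged for the sulfonamide-bearing chain, so a move back toward the level of compound 1 is expected. The expected step is a 3.0-fold lower number from compound 3 to compound 4 (0.48 log units; beyond the scatter), a lower number, because a 3.5-fold higher number from compound 1 to compound 3 (0.54 log units; beyond the scatter) was of modest size. Compound 4 is estimated at 4500 nM, within a range of 1800 nM to 12000 nM.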

Compound 4, half-maximal inhibitory concentration: 25500 nM
The estimate for compound 4 lay 5.7-fold (0.75 log units) below the measured number; the whole stated range lies below it.
By their numbers in this assay, from the lowest: compound 1; then compounds 3, 4 and 2 (each within the scatter of the next).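

In this assay, a six-membered aromatic ring at this carbon does not by itself give the low number: with methyl in place of bromo there is (a 6.5-fold higher number from compound 1 to compound 4 (0.81 log units; beyond the scatter)). 4-Methylphenyl cannot be told apart from the sulfonamide-bearing chain (a 1.9-fold higher number from compound 3 to compound 4 (0.27 log units; within the scatter)) or from cyclopropyl (a 1.0-fold lower number from compound 2 to compound 4 (0.02 log units; within the scatter)), so among these four only compound 1 stands apart. No measured data on these compounds account for the gap between bromo and methyl.

From the compounds shown here alone, whether the lower number is specific to bromo remains open. 4-Iodophenyl, 4-methoxyphenyl or 4-aminophenyl at this carbon would test that.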